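Swapping the chain terminus of compound 1 for an acetamide

The source may hold more compounds than are shown below. What is called first, only, known or untested is meant among the compounds shown, and "the series" means these compounds.

Of the compounds shown here, three sharing one core have been measured in a functional assay on HT cells (Homo sapiens) for antiproliferative activity, read by fluorescence, with a stated time of 72 h; on this read-out higher numbers stand for weaker inhibition of growth and lower numbers for stronger inhibition of growth. Compound 1 `CC(C)c1n[nH]c2c(NCc3ccc(-c4ccccn4)cc3)nc(SCCCN(C)C)nc12` gives 105 nM. Compound 2 `CC(C)c1n[nH]c2c(NCc3ccc(-c4ccccn4)cc3)nc(SCCn3ccnc3)nc12` carries an imidazolyl group at the end of the chain and gives 155 nM, while compound 3 `CC(C)c1n[nH]c2c(NCc3ccc(-c4ccccn4)cc3)nc(SCCCO)nc12` ends in a hydroxy group and gives 109 nM. Compound 1 shows the lowest of the three numbers, yet the steps of a 1.5-fold higher number from compound 1 to compound 2 (0.17 log units; within the scatter) and a 1.0-fold higher number from compound 1 to compound 3 (0.02 log units; within the scatter) both sit within the scatter, so no real difference among them can be claimed.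

Compound 4 `CC(=O)NCCSc1nc(NCc2ccc(-c3ccccn3)cc2)c2[nH]nc(C(C)C)c2n1` is the next compound to be measured. It differs from compound 1 in one place: acetamido in place of (dimethylamino)methyl on a saturated chain carbon, two bonds along the chain from a sulfur.

Among the compounds with values here, the steps that bear on this change are those where the same chain end was altered. Because a 1.0-fold higher number from compound 1 to compound 3 (0.02 log units; within the scatter) and a 1.5-fold higher number from compound 1 to compound 2 (0.17 log units; within the scatter) both stayed within the scatter, a change of the chain terminus here is expected to leave this assay largely unchanged. For compound 4 the expected step is a 1.2-fold higher number from compound 1 to compound 4 (0.08 log units; within the scatter), and the expected value is 125 nM, with a range from 55 nM to 280 nM.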

Compound 4, concentration for 50% growth inhibition: 71 nM
The estimate for compound 4 lay 1.8-fold (0.25 log units) above the measured number; the measured number falls inside the stated range.
By their numbers in this assay, from the lowest: compounds 4, 1, 3 and 2 (each within the scatter of the next, the first and the last beyond it).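

The acetamido end fits the pattern of the earlier chain ends in this assay: neither a 1.5-fold lower number from compound 1 to compound 4 (0.17 log units; within the scatter) nor a 1.5-fold lower number from compound 3 to compound 4 (0.19 log units; within the scatter) can be told from repeat-measurement noise, so the 2-acetamidoethyl chain performs on a par with the 3-(dimethylamino)propyl and hydroxy-ending chains. Within the data shown here, what is new is the first step at this position to clear the scatter, a 2.2-fold lower number from compound 2 to compound 4 (0.34 log units; beyond the scatter), a modest gap and the only separation among the four chain ends. No measurement here explains that gap or why the position tolerates these different ends.

Going by these compounds, whether a carboxylic acid or a primary amine at the chain end would stay in the same range remains open. So does whether a longer chain carrying the acetamido group would widen the modest gap or close it.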